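Swapping the aryl group on the triazole nitrogen

The compounds below may be only part of what the source reports. "The series", "measured", "known", "first", "only" and "open" are said of these compounds alone.

Compound 2 `O=C(Nc1cccc(OCc2cn(-c3ccc(Cl)cc3)nn2)c1)Nc1ccc(Cl)c(C(F)(F)F)c1` is the lower of the two numbers seen so far: in a functional assay on HepG2 cells (Homo sapiens) for inhibition, read by MTT assay, with a stated time of 72 h (a higher number here means a weaker inhibitor, a lower number a stronger inhibitor), compound 2 gives 2490 nM, while compound 1 `CCc1cccc(-n2cc(COc3cccc(NC(=O)Nc4ccc(Cl)c(C(F)(F)F)c4)c3)nn2)c1` gives 37900 nM. Compound 3 `O=C(Nc1cccc(OCc2cn(-c3cccc(C(F)(F)F)c3)nn2)c1)Nc1ccc(Cl)c(C(F)(F)F)c1` differs from compound 2 by 3-(trifluoromethyl)phenyl in place of 4-chlorophenyl on an aromatic nitrogen. For the measured compounds named here, only one step bears on this position, a 15-fold lower number from compound 1 to compound 2 (1.18 log units; beyond the scatter), which shows that the group on this nitrogen matters a great deal. Because compound 1 with its 3-ethylphenyl gives 37900 nM, a group again on the 3-position is expected to push the number back up, giving for compound 3 an estimated 7000 nM within 1500 nM to 30000 nM, a step of a 2.8-fold higher number from compound 2 to compound 3 (0.45 log units; beyond the scatter).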

Compound 3, half-maximal inhibitory concentration: 1270 nM
For compound 3 the middle estimate is 5.5-fold (0.74 log units) above the measured one; the measured number lies below the stated range.
By their numbers in this assay, from the lowest: compounds 3 and 2 (each within the scatter of the next); then compound 1.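

The step of a 2.0-fold lower number from compound 2 to compound 3 (0.29 log units; within the scatter) in this assay means that 3-(trifluoromethyl)phenyl and 4-chlorophenyl cannot be told apart on this nitrogen. Trifluoromethyl in place of ethyl on an aromatic carbon gives a 30-fold lower number from compound 1 to compound 3 (1.47 log units; beyond the scatter), so the weak number of compound 1 goes with the ethyl group itself, not simply with a group on that ring carbon. No measurement available here explains this difference.

On these data alone, it remains open how a ring carrying an amine, a carboxylic acid or a chain longer than ethyl would behave on this nitrogen.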